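Aryl substituent change on the shared core: compound 3 to 4

This account rests on a few compounds, and the source may have more. Where it says the series, first, only, none or still open, it means among the compounds named here.

Measured in an assay on isolated protein for agonist activity at Free fatty acid receptor 1 (Homo sapiens); a higher number here means that more compound is needed for the effect, a lower number that less compound is needed:
- compound 1 `CC#CC(CC(=O)O)c1ccc(OCc2ccc3nc(-c4ccc(CC)cc4)cn3c2)cc1` gives 496 nM
- compound 2 `CC#CC(CC(=O)O)c1ccc(OCc2ccc3nc(-c4ccc(OC)cc4)cn3c2)cc1` gives 47 nM
- compound 3 `CC#CC(CC(=O)O)c1ccc(OCc2ccc3nc(-c4ccc(F)cc4F)cn3c2)cc1` gives 825 nM

Compound 3 stands highest of the three numbers; compound 1 is nearest (a 1.7-fold higher number from compound 1 to compound 3 (0.22 log units; within the scatter)) and compound 2 furthest (an 18-fold higher number from compound 2 to compound 3 (1.24 log units; beyond the scatter)). Compound 4 `CC#CC(CC(=O)O)c1ccc(OCc2ccc3nc(-c4ccc(C(C)C)cc4)cn3c2)cc1` differs from compound 3 by 4-isopropylphenyl in place of 2,4-difluorophenyl on an aromatic carbon. Among the compounds with values here, the only measured step that bears on this swap is the one from compound 1 to compound 3 (a 1.7-fold higher number from compound 1 to compound 3 (0.22 log units; within the scatter)), which exchanges a 4-alkylphenyl against the 2,4-difluorophenyl and stays within the scatter. Within the data shown here, no measured pair compares ethyl with isopropyl, and the step from compound 1 to compound 2 (an 11-fold lower number from compound 1 to compound 2 (1.02 log units; beyond the scatter)) concerns methoxy and does not transfer. Compound 4 is therefore expected near compound 1, with a 1.7-fold lower number from compound 3 to compound 4 (0.22 log units; within the scatter) expected. The estimate for compound 4 is 500 nM, range 180 nM to 1400 nM.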

Compound 4, half-maximal effective concentration: 528 nM
Beside the measured number, compound 4's estimate is 1.1-fold (0.02 log units) below it, and the stated range covers the measured number.
By their numbers in this assay, from the lowest: compound 2; then compounds 1, 4 and 3 (each within the scatter of the next).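

In this assay the branched 4-isopropylphenyl and the 4-ethylphenyl cannot be told apart (a 1.1-fold higher number from compound 1 to compound 4 (0.03 log units; within the scatter)), and exchanging 2,4-difluorophenyl for 4-isopropylphenyl also stays within the scatter (a 1.6-fold lower number from compound 3 to compound 4 (0.19 log units; within the scatter)). Methoxy remains the only group here that stands apart, and isopropyl in its place gives an 11-fold higher number from compound 2 to compound 4 (1.05 log units; beyond the scatter), so a second alkyl group also falls short of methoxy. No evidence on the cause of this separation is available. From the compounds shown here alone, whether the oxygen atom itself matters remains open; ethoxy or hydroxyl on the same aryl ring would address this.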